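The source may report more compounds than this note shows. Statements on the series, on what has been measured and on what is new or still open speak of the compounds shown alone.

The measured compounds:
compound 1, `CC(=O)/C(=C\c1c(-c2ccccc2)[nH]c2ccccc12)S(=O)(=O)c1ccccc1`, 1400 nM
compound 2, `COc1ccc2[nH]c(-c3ccccc3)c(/C=C(\C#N)S(=O)(=O)c3ccccc3)c2c1`, 18700 nM

Two compounds share the core and the phenylsulfonyl-bearing vinyl arm and have been tested in a functional assay on HCC 2998 cells (Homo sapiens) for inhibition, read by sulforhodamine B assay, with a stated time of 48 h; a higher number here means a weaker inhibitor of growth, a lower number a stronger inhibitor of growth. Compound 1, with an acetyl group on the vinyl carbon, gives 1400 nM. Compound 2, which carries a nitrile on that carbon and a methoxy on the fused benzene ring, gives 18700 nM, the highest of the two numbers; the gap to compound 1 lies beyond the scatter. Since the two differ in more than one place, the data do not say which of the two changes carries the gap.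

Compound 3, `N#C/C(=C\c1c(-c2ccccc2)[nH]c2ccccc12)S(=O)(=O)c1ccccc1`, is not yet measured. It differs from compound 2 by hydrogen in place of methoxy on an aromatic carbon, the nitrile being kept. For the measured compounds named here, with no single-point step available, the effect of removing the methoxy is open. Compound 3 is expected to remain on the weaker side, with an estimated step of a 1.9-fold lower number from compound 2 to compound 3 (0.27 log units; within the scatter) that may well fall within the scatter. The estimate for compound 3 in this assay is 10000 nM, within 2500 nM to 40000 nM.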

Compound 3, concentration for 50% growth inhibition: 10900 nM
The estimate for compound 3 lay 1.1-fold (0.04 log units) below the measured number; measured number inside the range.
By their numbers in this assay, from the lowest: compound 1; then compounds 3 and 2 (each within the scatter of the next).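

With the nitrile kept, hydrogen in place of methoxy on an aromatic carbon gives a 1.7-fold lower number from compound 2 to compound 3 (0.23 log units; within the scatter) in this assay, so this measurement does not tell the two groups apart at this place. Cyano in place of acetyl on the double-bonded chain carbon gives a 7.8-fold higher number from compound 1 to compound 3 (0.89 log units; beyond the scatter), and this step lies beyond the scatter, so the gap between compound 1 and compound 2, which could not be assigned before, can now be placed largely on the exchange of acetyl for nitrile rather than on the methoxy. No further data are available to explain either step.

The compounds shown leave open whether methoxy would also make no clear difference with acetyl kept on the chain carbon, since the one methoxy comparison here carries a nitrile. They also leave open how an ester or a carboxylic acid on that chain carbon, or a hydroxyl or a chlorine on the aromatic carbon, would compare in this assay.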